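The source may report more compounds than this note shows. Statements on the series, on what has been measured and on what is new or still open speak of the compounds shown alone.

Measured so far in a functional assay on A-375 cells (Homo sapiens) for cytotoxicity, read by MTT assay, with a stated time of 72 h, tested at 1 uM; on this read-out lower numbers stand for less inhibition of growth and higher numbers for more inhibition of growth at the one concentration tested:
compound 1 `N/C(=N\NC(=S)N1CCN(c2ccccn2)CC1)c1ccc(F)cn1` gives 49.3%
compound 2 `N/C(=N\NC(=S)N1CCCC1)c1ccc(F)cn1` gives 57.9%
compound 3 `Cc1ccnc(/C(N)=N/NC(=S)N2CCSCC2)c1` gives 47.7%

Compound 2 stands at the highest of these three numbers. Its nearest neighbour is compound 1, whose value lies within the scatter of compound 2; the furthest is compound 3, whose value lies beyond it.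

Compound 4 `N/C(=N\NC(=S)N1CCSCC1)c1ccc(F)cn1` differs from compound 2 in one place: thiomorpholin-4-yl in place of pyrrolidin-1-yl on a thiocarbonyl carbon. Among the compounds with values here, no measured pair shows this exact change. Compound 3 also carries thiomorpholin-4-yl, on a different core, and gives a number below compound 2 in this assay. Compound 4 is therefore expected to come in somewhat lower than compound 2, a step of a number 7.9 percentage points lower from compound 2 to compound 4 (within the scatter) that is expected to stay within the scatter. The estimate for compound 4 is 50%, with a range from 38% to 62%.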

Compound 4, percent growth inhibition at one concentration: 55.1%
Compound 4: middle estimate off by 5.1 percentage points, on the low side, and the stated range covers the measured number.
By their numbers in this assay, from the lowest: compounds 3, 1, 4 and 2 (each within the scatter of the next, the first and the last beyond it).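

In this assay, thiomorpholin-4-yl in place of pyrrolidin-1-yl on a thiocarbonyl carbon amounts to a number 2.8 percentage points lower from compound 2 to compound 4 (within the scatter) on the shared core. Within the data shown here, this is the first direct one-place reading at this position, and it shows that a six-membered ring holding sulfur is accommodated there about as well as the five-membered ring without it. Nothing available bears on why the read-out holds. Still open, as far as these compounds go, is how a dimethylamino group or a morpholin-4-yl ring would read at this place, and whether the same change behaves alike on other cores.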